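Fluoro on the Ring: Expected Dose in Mice

The source may report more compounds than this note shows. Statements on the series, on what has been measured and on what is new or still open speak of the compounds shown alone.

Measured so far in a functional assay on the whole organism (strain Swiss) with Mus musculus as the target; on this read-out higher numbers stand for an effect only at larger amounts of compound and lower numbers for an effect already at smaller amounts:
- compound 1, `CC(C(=O)Nc1ccccc1)N1C(=O)CCC1=O`: 44.3 mg/kg
- compound 2, `CCC(C(=O)Nc1ccccc1)N1C(=O)CCC1=O`: 69.3 mg/kg

Of the compounds shown here, two have been measured, and they share one core. Compound 2 differs from compound 1 only by a methyl in place of hydrogen on a saturated chain carbon; in this assay the step is a 1.6-fold higher number from compound 1 to compound 2 (0.19 log units; within the scatter), so the two numbers are within the scatter of each other and neither compound can be set above the other.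

Compound 3, `CCC(C(=O)Nc1cccc(F)c1)N1C(=O)CCC1=O`, is the next step from compound 2: fluoro in place of hydrogen on an aromatic carbon. Among the measured compounds shown here, no measured step touches the aromatic ring; the only step known concerns the chain. The structural record therefore gives no direction for this change, and the expectation is a number within the scatter of compound 2. Compound 3 is estimated at 69 mg/kg in this assay, between 35 mg/kg and 140 mg/kg, which means an expected step of a 1.0-fold lower number from compound 2 to compound 3 (0.00 log units; within the scatter).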

Compound 3, dose for half-maximal effect: 41.4 mg/kg
Estimate against measurement, compound 3: 1.7-fold (0.22 log units) above, and the stated range covers the measured number.
By their numbers in this assay, from the lowest: compounds 3, 1 and 2 (each within the scatter of the next).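

Among the compounds shown here, this is the first change on the aromatic ring, and in this assay fluoro in place of hydrogen, on a ring carbon meta to a large group, gives a 1.7-fold lower number from compound 2 to compound 3 (0.22 log units; within the scatter) and so cannot be told apart from no change at all. The earlier compounds shown here showed only that the chain could take a methyl within the scatter; now the same holds for a single fluoro on the ring, so this position accepts one small atom without a readable shift in the dose needed in mice. No separate measurement is at hand that could explain this result.

The compounds shown leave open whether a larger group at this position, such as trifluoromethyl or methoxy, would move the number beyond the scatter. They also leave open whether fluoro on another carbon of the ring would behave the same way.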